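Working notes on kinetic solubility across a small amide series

A few compounds are considered here, and "the series" means these few. Any claim that something is new, unique, unknown or untested is made for them only; others in the source may bear on it.

Measured so far:
compound 1 `COc1ccc2nc(C)cc(OCC(=O)Nc3cc(C)cc(C)c3)c2c1`: 26000 nM
compound 2 `Cc1cc(C)cc(NC(=O)COc2cc(C)nc3ccc(C(F)(F)F)cc23)c1`: 10000 nM
compound 3 `CCC(Oc1cc(C)nc2ccc(OC)cc12)C(=O)Nc1cc(C)cc(C)c1`: 123000 nM

In a physicochemical assay for solubility, in phosphate buffer, measured as kinetic solubility, with a stated time of 1 h, at pH 7.4 (a lower number here means a less soluble compound, a higher number a more soluble compound), compound 1 stands second highest of the three numbers. The nearest measured step is a 2.6-fold lower number from compound 1 to compound 2 (0.41 log units; beyond the scatter); the furthest is a 4.7-fold higher number from compound 1 to compound 3 (0.67 log units; beyond the scatter).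

Compound 4 `COc1ccc2nc(C)cc(OCC(=O)Nc3ccncc3)c2c1` is not yet measured. It differs from compound 1 by pyridin-4-yl in place of 3,5-dimethylphenyl on an amide-type nitrogen. Going by the values given here, neither measured step touches the amide-type nitrogen: one alters a group on an aromatic carbon of the shared core, the other a saturated chain carbon, so no measured step bears directly on this change. The two steps do show that single changes in this set move the number beyond the scatter in either direction. In this assay compound 4 is expected to show a step of a 3.1-fold higher number from compound 1 to compound 4 (0.49 log units; beyond the scatter), with wide uncertainty. The estimate for compound 4 in this assay is 80000 nM, expected to fall between 25000 nM and 250000 nM.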

Compound 4, solubility: 91500 nM
Beside the measured number, compound 4's estimate is 1.1-fold (0.06 log units) below it, and the stated range covers the measured number.
By their numbers in this assay, from the lowest: compound 2; then compound 1; then compounds 4 and 3 (each within the scatter of the next).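

In this assay, going by these compounds alone, pyridin-4-yl in place of 3,5-dimethylphenyl on the amide-type nitrogen gives a 3.5-fold higher number from compound 1 to compound 4 (0.55 log units; beyond the scatter), so this position, untouched by the earlier steps, also moves the number beyond the scatter. The entering group has 6 heavy atoms and 1 hydrogen-bond acceptor, the leaving group 8 heavy atoms and 0 hydrogen-bond acceptors. Nothing available ties the step to either difference.

The compounds shown leave open how an unsubstituted phenyl or a pyridin-3-yl on the amide-type nitrogen would read. Also open, from the compounds shown here alone, is whether the step holds with trifluoromethyl on the core or with ethyl on the saturated chain carbon.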